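This account rests on a few compounds, and the source may have more. Where it says the series, first, only, none or still open, it means among the compounds named here.

Among the measured compounds shown here, compound 1, `O=c1[nH]c2ncn(Cc3ccncc3)c2c(=O)n1O`, is the only compound of this small set for which a number is reported in an assay on isolated protein for inhibition of poly(A)-specific ribonuclease PARN (Homo sapiens); on this read-out higher numbers stand for weaker inhibition and lower numbers for stronger inhibition. In this assay compound 1 gives 245000 nM, a weak result by any standard. Two further members share its core. For compound 2, `O=c1[nH]c2ncn(CCOc3ccccc3)c2c(=O)n1O`, no result was obtained in this assay: "not determined" (no result reported). The same holds for compound 3, `CCCCOCCCn1cnc2[nH]c(=O)n(O)c(=O)c21`, which in this assay also stands as "not determined" (no result reported). Compound 1 therefore stands alone on the numbers shown, and no step between measured compounds can be drawn from it.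

The account now turns to compound 4, `O=c1[nH]c2ncn(Cc3ccccc3)c2c(=O)n1O`, which has not yet been measured. Its difference from compound 1 is phenyl in place of pyridin-4-yl on a saturated chain carbon bound to an aromatic nitrogen. Nothing in the data shows how a pyridin-4-yl against a phenyl at this place behaves in this assay, so the expectation rests on compound 1 alone. Because compound 1 gives 245000 nM, compound 4 is expected to stay close to that level, with a step from compound 1 to compound 4 estimated at a 1.1-fold lower number from compound 1 to compound 4 (0.05 log units; within the scatter), no more than the scatter of repeated measurements. Compound 4 is thus estimated to give 220000 nM, within a range from 70000 nM to 700000 nM.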

Compound 4, half-maximal inhibitory concentration: 84100 nM
Estimate against measurement, compound 4: 2.6-fold (0.42 log units) above; the range from low to high includes it.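

With this pair, this assay gives its first reading of the group on a saturated chain carbon bound to an aromatic nitrogen: phenyl in place of pyridin-4-yl gives a 2.9-fold lower number from compound 1 to compound 4 (0.46 log units; beyond the scatter), a modest change, but one that shows this place can shift the read-out towards stronger inhibition, although compound 4 at 84100 nM remains weak. The two groups match in size and differ only in that the ring nitrogen of pyridin-4-yl, with its hydrogen-bond acceptor, gives way to carbon, so the pyridine ring is not needed for the activity seen here. Nothing available explains why phenyl gives the lower number.

Steps involving compound 2 and compound 3 cannot be read, so the effect of a longer chain carrying an ether oxygen at this place stays unknown. Also open, going by these compounds, is whether a substituent on the phenyl ring, such as a carboxylic acid, an amine or a chlorine atom, would move the number further, and whether a pyridin-3-yl group would behave like phenyl or like pyridin-4-yl.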